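Swapping the hydrazone aryl group: from dichlorophenyl to thiophene

This account rests on a few compounds, and the source may have more. Where it says the series, first, only, none or still open, it means among the compounds named here.

Measured compounds:
- compound 1, `Cn1c(=O)c(=O)n(C2CCCC2)c2nc(N/N=C/c3ccc(Cl)cc3)ncc21`: 8420 nM
- compound 2, `Cn1c(=O)c(=O)n(C2CCCC2)c2nc(N/N=C/c3cccc(Cl)c3Cl)ncc21`: 17200 nM

Both compounds share one core and differ only in the aromatic group attached to the hydrazone carbon. In a functional assay on PC-3 cells (Homo sapiens) for antiproliferative activity, read by MTT assay (a lower number here means a stronger inhibitor, a higher number a weaker inhibitor), compound 1 gives 8420 nM, and compound 2 gives 17200 nM. Of these two numbers compound 2 holds the higher one, which means it is the weaker inhibitor; the step of a 2.0-fold higher number from compound 1 to compound 2 (0.31 log units; beyond the scatter) is modest but beyond the scatter.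

Compound 3, `Cn1c(=O)c(=O)n(C2CCCC2)c2nc(N/N=C/c3cccs3)ncc21`, has not yet been measured. It differs from compound 2 in one place: thiophen-2-yl in place of 2,3-dichlorophenyl on a carbon with a double bond to nitrogen. For the measured compounds named here, no measured step covers an exchange of a six-membered carbon ring for a five-membered ring with a sulfur atom, so the only guide is that changing the aryl group in this position moved the number by a 2.0-fold higher number from compound 1 to compound 2 (0.31 log units; beyond the scatter), a modest amount. A step of similar or smaller size, in either direction, therefore seems the most reasonable expectation for a 1.6-fold lower number from compound 2 to compound 3 (0.19 log units; within the scatter), and compound 3 is estimated at 11000 nM, with a plausible range from 3500 nM to 35000 nM.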

Compound 3, half-maximal inhibitory concentration: 75600 nM
For compound 3 the middle estimate is 6.9-fold (0.84 log units) below the measured one; the measured number lies above the stated range.
By their numbers in this assay, from the lowest: compound 1; then compound 2; then compound 3.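

The thiophen-2-yl group is not an equal stand-in for a chlorinated phenyl ring at this position. In this assay, the exchange gives a 4.4-fold higher number from compound 2 to compound 3 (0.64 log units; beyond the scatter), and measured against the other chlorinated compound it gives a 9.0-fold higher number from compound 1 to compound 3 (0.95 log units; beyond the scatter), so compound 3 is the weakest of the three, and the step away from either chlorinated phenyl ring is larger than the one between them, a 2.0-fold higher number from compound 1 to compound 2 (0.31 log units; beyond the scatter). Swapping one chlorinated phenyl ring for another therefore shifted the number less than replacing the ring with thiophen-2-yl, and no measurement shown here explains why the thiophene compound is weaker.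

This exchange alters several things at once: the ring goes from six-membered to five-membered, sulfur enters, and both chlorine atoms leave, so the compounds shown cannot say which of these changes matters. A plain phenyl ring without chlorine and a thiophene ring carrying a chlorine atom would help pull these apart, while a pyridine ring or a phenyl ring bearing an amine would show how this position responds to a basic nitrogen.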